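Phenylsulfonyl for 3-chlorobenzyl on the shared aromatic nitrogen

The compounds below may be only part of what the source reports. "The series", "measured", "known", "first", "only" and "open" are said of these compounds alone.

Measured compounds:
compound 1, `C[C@H](NCc1ccc(OCCCCCN2CCN(c3cccc4c3ccn4Cc3cccc(Cl)c3)CC2)cc1)C(N)=O`, 232 nM
compound 2, `C[C@H](NCc1ccc(OCCCCCN2CCN(c3cccc4c3ccn4S(=O)(=O)c3ccccc3)CC2)cc1)C(N)=O`, 65 nM
compound 3, `C#CCN(C)Cc1ccc(OCCCCN2CCN(c3cccc4c3ccn4Cc3cccc(Cl)c3)CC2)cc1`, 195 nM

All numbers come from an assay on HEK293 cells for displacement of a labelled ligand from 5-hydroxytryptamine receptor 6 (Homo sapiens), read by scintillation counting, with a stated time of 1 h; on this read-out lower numbers stand for stronger inhibition and higher numbers for weaker inhibition. Compound 1 and compound 2 form a matched pair: the change is phenylsulfonyl in place of 3-chlorobenzyl on an aromatic nitrogen, and it brought a 3.6-fold lower number from compound 1 to compound 2 (0.55 log units; beyond the scatter). Compound 3 carries the same 3-chlorobenzyl group as compound 1 but a different core; the difference between the two cores is not broken down here. In this assay compound 3 gives 195 nM, and compound 1 gives 232 nM, so the two stand within the scatter of each other and no order can be read from them.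

Compound 4, `C#CCN(C)Cc1ccc(OCCCCN2CCN(c3cccc4c3ccn4S(=O)(=O)c3ccccc3)CC2)cc1`, is not yet measured. It differs from compound 3 by phenylsulfonyl in place of 3-chlorobenzyl on an aromatic nitrogen, the same change, at the same place, as between compound 1 and compound 2; the change appears in two pairs among the compounds shown. Going by the values given here, because the one measured instance of this change is a 3.6-fold lower number from compound 1 to compound 2 (0.55 log units; beyond the scatter), and because, near compound 1, compound 3 starts with 195 nM, a step of similar size is expected here, and compound 4 is estimated to lie at 58 nM, between 25 nM and 150 nM. The expected step is a 3.4-fold lower number from compound 3 to compound 4 (0.53 log units; beyond the scatter). This rests on a single pair only, so the range is set wide.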

Compound 4, inhibition constant: 54 nM
The estimate for compound 4 lay 1.1-fold (0.03 log units) above the measured number; low and high end bracket the measured number.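

In this assay, phenylsulfonyl in place of 3-chlorobenzyl on the aromatic nitrogen gives a 3.6-fold lower number from compound 3 to compound 4 (0.56 log units; beyond the scatter) in the second pair. Set beside the first pair, the step shows no readable difference between the core of compound 1 and the core of compound 3: the same change on two cores in this assay, a 3.6-fold lower number (0.55 log units; beyond the scatter) from compound 1 to compound 2 and a 3.6-fold lower number (0.56 log units; beyond the scatter) from compound 3 to compound 4, 1.0-fold (0.01 log units) apart, within the scatter of two such steps.
So within this series the change carries over between these two cores with its size intact, but this rests on two pairs in a single assay: it does not show that the step would hold on a third core, and it gives no reason for the lower number.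

The change replaces the chlorine, the methylene link and the sulfonyl at one stroke, so the compounds shown leave open which part of it carries the step; a plain benzyl or a 3-chlorophenylsulfonyl group on the same nitrogen would begin to separate these parts. Also open, from the compounds shown here alone, is how far the step extends beyond the two cores, which differ together in chain and amine end, for instance with a longer chain alone, a carboxylic acid in place of the primary amide, or a methylsulfonyl group on the aromatic nitrogen.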